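A Methyl on the Furan of Compound 2

The source may hold more compounds than are shown below. What is called first, only, known or untested is meant among the compounds shown, and "the series" means these compounds.

Compound 2 `O=c1[nH]/c(=C\c2ccco2)c(=O)[nH]/c1=C\c1cccc(Oc2ccc(F)cc2)c1` joins a furan-2-yl to one double-bonded chain carbon of the shared core and a fluorophenoxy-bearing phenyl to the other. Among the measured compounds shown here, in a functional assay on NCI-H460 cells (Homo sapiens) for cytotoxicity, read by MTT assay, with a stated time of 72 h (on this read-out lower numbers stand for stronger inhibition and higher numbers for weaker inhibition), compound 2 gives 155 nM, the only number among the two values shown for this series. Compound 1 `O=c1[nH]/c(=C\c2cccc(Oc3ccc(F)cc3)c2)c(=O)[nH]/c1=C\c1cccnc1` gives in this assay only > 1000 nM, which is a limit of the assay and not a number (the limit of > 1000 nM in this assay, at which 1 of the 2 values shown sits). For the measured compounds named here, the single measured step, an at least 6.4-fold lower number from compound 1 to compound 2 (0.80 log units; beyond the scatter), concerns the exchange of the whole ring at that chain carbon, not a substituent on it.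

Compound 3 `Cc1ccc(/C=c2\[nH]c(=O)/c(=C/c3cccc(Oc4ccc(F)cc4)c3)[nH]c2=O)o1` has yet to be measured in this assay. It differs from compound 2 by methyl in place of hydrogen on an aromatic carbon, with the group sitting next to the ring oxygen of the furan. Going by the values given here, no measured step bears on such a small addition to the furan-2-yl, so there is no ground to expect a step beyond the scatter in this assay in either direction. Compound 3 is therefore expected near 150 nM, within 60 nM to 400 nM, corresponding to an estimated step of a 1.0-fold lower number from compound 2 to compound 3 (0.01 log units; within the scatter).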

Compound 3, half-maximal inhibitory concentration: 30 nM
Beside the measured number, compound 3's estimate is 5.0-fold (0.70 log units) above it; measured number below the stated range.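

In this assay, the earlier step spoke only to exchanging the whole ring, whereas here a single methyl, one heavy atom with no hydrogen-bond donors or acceptors, placed next to the ring oxygen of the furan, gives a 5.2-fold lower number from compound 2 to compound 3 (0.71 log units; beyond the scatter). So the number responds to a small substituent on the ring at this chain carbon and not only to the identity of the ring, and the 5-methylfuran-2-yl in place of the pyridin-3-yl gives an at least 33-fold lower number from compound 1 to compound 3 (1.52 log units; beyond the scatter). That comparison rests on a limit of the assay for compound 1 and not on a number: the limit of > 1000 nM in this assay, at which 1 of the 3 values shown sits.

The compounds shown carry only methyl at this furan position, so they leave open whether ethyl, methoxy, a chlorine atom or an amine in the same place would move the number in the same direction, or by a similar amount. They also leave open whether methyl would act alike on the pyridin-3-yl of compound 1, and whether the step holds with a different group in place of the fluorophenoxy-bearing phenyl, which stays the same throughout.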